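Lengthening a methoxy-ended chain on the shared core

A few compounds are considered here, and "the series" means these few. Any claim that something is new, unique, unknown or untested is made for them only; others in the source may bear on it.

Measured in a functional assay on RAW264.7 cells (Mus musculus) for inhibition, read by Griess assay, with stated times of 1 h and 24 h; a higher number here means a weaker inhibitor, a lower number a stronger inhibitor:
- compound 1 `COc1ccc(C(O)C2OC(=O)c3c(OC)cc(OC)cc32)cc1`: > 10000 nM (a limit)
- compound 2 `CCCCOc1ccc(C(O)C2OC(=O)c3c(OC)cc(OC)cc32)cc1`: 1800 nM
- compound 3 `COCCOc1ccc(C(O)C2OC(=O)c3c(OC)cc(OC)cc32)cc1`: > 10000 nM (a limit)

Compound 3 has no exact number, since compound 3 reports only the limit > 10000 nM. This is the limit of > 10000 nM in this assay, at which 2 of the 3 values shown sit.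

Compound 4 `COCCCCOc1ccc(C(O)C2OC(=O)c3c(OC)cc(OC)cc32)cc1` alters only the chain: 2-methoxyethyl in place of methoxy on a saturated chain carbon, two bonds along the chain from an oxygen on an aromatic ring. Here 2-methoxyethyl replaces methoxy on a saturated chain carbon, two bonds along the chain from an oxygen on an aromatic ring, so 2-methoxyethoxy becomes 4-methoxybutoxy.

Within the data shown here, three measured steps bear on this change. Extending the chain gave an at least 5.5-fold lower number from compound 1 to compound 2 (0.74 log units; beyond the scatter). Placing methoxy where ethyl stood gave an at least 5.5-fold higher number from compound 2 to compound 3 (0.74 log units; beyond the scatter). The third, a step that the two limits leave unreadable from compound 1 to compound 3, gives no usable size.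

Compound 4 keeps the methoxy ending of compound 3, which argues against a full recovery given an at least 5.5-fold higher number from compound 2 to compound 3 (0.74 log units; beyond the scatter). Its longer chain, however, suggests some gain given an at least 5.5-fold lower number from compound 1 to compound 2 (0.74 log units; beyond the scatter). A modest move towards a lower number is therefore expected, and the result could still stop at the limit.

The estimated change is an at least 2.2-fold lower number from compound 3 to compound 4 (0.34 log units; beyond the scatter).

For compound 4 the expected value is 4500 nM, with an estimated range from 1500 nM to 14000 nM.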

Compound 4, half-maximal inhibitory concentration: 8210 nM
The estimate for compound 4 lay 1.8-fold (0.26 log units) below the measured number; the measured number falls inside the stated range.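

Among these compounds, compound 4 is the first chain with a methoxy ending on the shared core to give an exact number in this assay, so lengthening 2-methoxyethoxy to 4-methoxybutoxy can now be compared with the shorter chains, giving an at least 1.2-fold lower number from compound 3 to compound 4 (0.08 log units; that floor lies within the scatter) and an at least 1.2-fold lower number from compound 1 to compound 4 (0.08 log units; that floor lies within the scatter). The methoxy ending can also now be sized between two exact numbers, at the chain length of the butoxy group, where methoxy in place of hydrogen, four bonds along the chain from an oxygen on an aromatic ring, gives a 4.6-fold higher number from compound 2 to compound 4 (0.66 log units; beyond the scatter). The first two comparisons yield only floors that cannot settle whether the longer chain brings any real gain, because compound 1 and compound 3 each carry a limit and not an exact number: the limit of > 10000 nM in this assay, at which 2 of the 4 values shown sit.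

The compounds shown leave open how an amine or a carboxylic acid at the end of the chain would compare with the methoxy ending, and whether a longer chain ending in methoxy would lower the number further. As far as these compounds go, how a hexyloxy chain would compare with the butoxy chain of compound 2 also stays open.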